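This account rests on a few compounds, and the source may have more. Where it says the series, first, only, none or still open, it means among the compounds named here.

Measured compounds in a functional assay on HCT-116 cells (Homo sapiens) for antiproliferative activity, read by MTT assay, with a stated time of 72 h; a lower number here means a stronger inhibitor, a higher number a weaker inhibitor:
- compound 1, `CN(C(=O)c1ccccc1)c1ccc2[nH]c(-c3n[nH]c4ccccc34)cc2n1`, gives 10600 nM
- compound 2, `COc1ccc(C(=O)N(C)c2ccc3[nH]c(-c4n[nH]c5ccccc45)cc3n2)cc1`, gives 29500 nM
- compound 3, `CN(C(=O)Nc1ccccc1)c1ccc2[nH]c(-c3n[nH]c4ccccc34)cc2n1`, gives 1.3 nM

Compounds 1 and 2 share a core, and compound 2 carries one change on it: methoxy in place of hydrogen on an aromatic carbon. That change moved the reading by a 2.8-fold higher number from compound 1 to compound 2 (0.44 log units; beyond the scatter), a modest step. Compound 3 differs from compound 1 in the core itself: anilino in place of phenyl on a carbonyl carbon. This change made the largest step in the set, an 8200-fold lower number from compound 1 to compound 3 (3.91 log units; beyond the scatter), and compound 3 also stands far from compound 2, by a 23000-fold lower number from compound 2 to compound 3 (4.36 log units; beyond the scatter). Among the three measured compounds, compound 3 has the lowest number, with every step to the others beyond the scatter.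

Compound 4, `COc1ccc(NC(=O)N(C)c2ccc3[nH]c(-c4n[nH]c5ccccc45)cc3n2)cc1`, has not yet been measured in this assay. It differs from compound 3 by methoxy in place of hydrogen on an aromatic carbon. The place is described in the same words as for the change from compound 1 to compound 2, so this is the same change carried over from the core of compound 1 to the core of compound 3; only the wider reading differs, anilino to (4-methoxyphenyl)amino here rather than benzoyl to (4-methoxyphenyl)carbonyl.

The step from compound 3 to compound 4 is expected to be small and in the same direction, a 2.7-fold higher number from compound 3 to compound 4 (0.43 log units; beyond the scatter), because the same change gave a 2.8-fold higher number from compound 1 to compound 2 (0.44 log units; beyond the scatter) on the other core. Among the measured compounds shown here, compound 4 is therefore estimated at 3.5 nM, with a range from 1 nM to 15 nM, on the single earlier instance of this change.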

Compound 4, half-maximal inhibitory concentration: 63 nM
For compound 4 the middle estimate is 18-fold (1.26 log units) below the measured one; measured number above the stated range.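

In this assay, methoxy in place of hydrogen on an aromatic carbon raised the number on both cores, but the size of the step did not carry over from one core to the other: the same change on two cores in this assay, a 2.8-fold higher number (0.44 log units; beyond the scatter) from compound 1 to compound 2 and a 48-fold higher number (1.69 log units; beyond the scatter) from compound 3 to compound 4, 17-fold (1.24 log units) apart, beyond the scatter of two such steps

On the core of compound 3 the change moved the reading by a 48-fold higher number from compound 3 to compound 4 (1.69 log units; beyond the scatter), yet the anilino-type linkage still gave much lower numbers with the methoxy present, by a 470-fold lower number from compound 2 to compound 4 (2.67 log units; beyond the scatter) and by a 170-fold lower number from compound 1 to compound 4 (2.23 log units; beyond the scatter). Among the compounds shown here, this shows that the direction of the methoxy step held across the two cores while its size depended on the core, so the step measured on one core was a poor guide to its size on the other; with only two pairs, it does not show why the steps differ or how the change would behave on any further core.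

The compounds shown leave open whether a different group at the same place, such as chlorine, hydroxy or ethoxy, would follow the large step or the modest one. They also leave open whether the larger step holds when methoxy sits elsewhere on the ring, or when the methyl on the linking nitrogen gives way to hydrogen.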